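This account rests on a few compounds, and the source may have more. Where it says the series, first, only, none or still open, it means among the compounds named here.

Three analogues on the shared core have numbers in an assay for inhibition of serine/threonine-protein kinase 3 (Homo sapiens), read by luminescence and ADP-Glo, in the presence of a further agent that is not named here; a higher number here means a weaker inhibitor, a lower number a stronger inhibitor. Compound 1 `Clc1cccc(-c2c[nH]c3ncnc(NCC4CC4)c23)c1` gives 213 nM, compound 2 `CNC1CCN(c2ncnc3[nH]cc(-c4cccc(Cl)c4)c23)CC1` gives 293 nM, and compound 3 `CC(=O)NC1CCN(c2ncnc3[nH]cc(-c4cccc(Cl)c4)c23)CC1` gives 36 nM, so compound 3 stands lowest of the three. The step of a 1.4-fold higher number from compound 1 to compound 2 (0.14 log units; within the scatter) lies within the scatter, whereas the step of an 8.1-fold lower number from compound 2 to compound 3 (0.91 log units; beyond the scatter) lies beyond it. Compound 4 `Clc1cccc(-c2c[nH]c3ncnc(N4CCCCC4)c23)c1` differs from compound 3 by hydrogen in place of acetamido on a saturated ring carbon. The step from compound 2 to compound 3 bears most on this, since the acetyl that entered there is part of the acetamido that leaves here, and removing it altogether is expected to undo roughly that gain. For compound 4 the expected number is 250 nM, within 80 nM to 800 nM, an estimated step of a 6.9-fold higher number from compound 3 to compound 4 (0.84 log units; beyond the scatter).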

Compound 4, half-maximal inhibitory concentration: 167 nM
Beside the measured number, compound 4's estimate is 1.5-fold (0.18 log units) above it, and the stated range covers the measured number.
By their numbers in this assay, from the lowest: compound 3; then compounds 4, 1 and 2 (each within the scatter of the next).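

In this assay, the plain piperidin-1-yl gives a reference for this saturated ring carbon: a 4.6-fold higher number from compound 3 to compound 4 (0.67 log units; beyond the scatter) shows that acetamido there gives a lower number than hydrogen, while a 1.8-fold lower number from compound 2 to compound 4 (0.24 log units; within the scatter) does not separate methylamino from hydrogen. On the aromatic carbon, a 1.3-fold lower number from compound 1 to compound 4 (0.11 log units; within the scatter) likewise does not separate piperidin-1-yl from (cyclopropylmethyl)amino. No evidence is available to explain the acetamido result.

Open, from the compounds shown here alone, is whether the result extends beyond acetyl: a propanoyl group, a methanesulfonyl group or a methyl urea on the same amine nitrogen would test this.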